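This account rests on a few compounds, and the source may have more. Where it says the series, first, only, none or still open, it means among the compounds named here.

Measured in a functional assay on A-375 cells (Homo sapiens) for inhibition, read by CCK-8 assay, with a stated time of 72 h, tested at 8 uM; on this read-out higher numbers stand for more inhibition of growth at the one concentration tested and lower numbers for less inhibition of growth:
Compound 1 `COc1ccc(SCc2ccc(/C=C/C(=O)Nc3ccccc3N)cc2)cc1OC`: 46.4%
Compound 2 `Cc1cc(C)cc(SCc2ccc(/C=C/C(=O)Nc3ccccc3N)cc2)c1`: 2.49%
Compound 3 `Nc1ccccc1NC(=O)/C=C/c1ccc(CSCCc2ccccc2)cc1`: 37.4%

These three compounds share one core and differ only in the group on a sulfur. The phenethyl member stands close to one neighbour and far from the other. The data show a number 9 percentage points lower from compound 1 to compound 3 (within the scatter), and also a number 34.9 percentage points higher from compound 2 to compound 3 (beyond the scatter).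

The next compound is compound 4 `CC(C)(C)c1ccc(SCc2ccc(/C=C/C(=O)Nc3ccccc3N)cc2)cc1`, where 4-(tert-butyl)phenyl takes the place of phenethyl on a sulfur: 4-(tert-butyl)phenyl in place of phenethyl on a sulfur.

Among the compounds with values here, no measured step makes this exact exchange, so the evidence is indirect. The two compounds with a substituted phenyl group on the sulfur set the range, and they differ widely, with a number 43.9 percentage points lower from compound 1 to compound 2 (beyond the scatter). Compound 4 resembles compound 2 in carrying only carbon on its phenyl group, and compound 2 gives 2.49%. That resemblance points downward in this assay, but two compounds are thin support, and compound 1 at 46.4% goes against any simple reading.

A moderate drop is therefore expected, with wide uncertainty, and the estimate is a number 17.4 percentage points lower from compound 3 to compound 4 (beyond the scatter). For compound 4 the expected value is 20%, with an estimated range of 3% to 45%.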

Compound 4, percent growth inhibition at one concentration: 35.5%
Compound 4: the middle estimate sits 15.5 percentage points below what was measured; the measured number falls inside the stated range.
By their numbers in this assay, from the lowest: compound 2; then compounds 4, 3 and 1 (each within the scatter of the next, the first and the last beyond it).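

In this assay the step of a number 33 percentage points higher from compound 2 to compound 4 (beyond the scatter) shows that a phenyl group carrying only carbon on a sulfur need not give a number as low as that of compound 2, which now stands apart as the lowest of the four compounds. The exchange of phenethyl for 4-(tert-butyl)phenyl gives a number 1.9 percentage points lower from compound 3 to compound 4 (within the scatter) and so leaves the read-out unchanged within the scatter, showing that this position accepts both an aromatic ring held on a chain and a directly attached phenyl group. The step of a number 10.9 percentage points lower from compound 1 to compound 4 (beyond the scatter) is modest, so compound 4 does not fully match the 3,4-dimethoxyphenyl member, although it remains far closer to it than to the 3,5-dimethylphenyl member.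

Still open, going by these compounds, is how an amine, a carboxylic acid or a longer chain on a sulfur would read in this assay, and single-concentration numbers from four compounds give only a coarse picture of this position. Nothing in the available evidence accounts for why compound 2 alone sits so far from the other three.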